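A few compounds are considered here, and "the series" means these few. Any claim that something is new, unique, unknown or untested is made for them only; others in the source may bear on it.

Compounds measured in a functional assay on MIA PaCa-2 cells (Homo sapiens) for antiproliferative activity, read by sulforhodamine B assay, with a stated time of 48 h; on this read-out lower numbers stand for stronger inhibition of growth and higher numbers for weaker inhibition of growth:
compound 1 `O=C(NCc1cn(Cc2ccc(F)cc2)nn1)c1cn(-c2ccccc2)nc1-c1ccccc1`: 9600 nM
compound 2 `COc1ccc(Cn2cc(CNC(=O)c3cn(-c4ccccc4)nc3-c3ccc(Cl)cc3)nn2)cc1OC`: 9400 nM
compound 3 `COc1ccc(-c2nn(-c3ccccc3)cc2C(=O)NCc2cn(Cc3ccc(F)cc3)nn2)cc1`: 24100 nM

Within the data shown here, compound 3 gives the highest of these three numbers in this assay, so of the three it inhibits growth the least; the single change a 2.5-fold higher number from compound 1 to compound 3 (0.40 log units; beyond the scatter) separates it from compound 1, while compound 2 and compound 1 sit close together. Compound 4 `COc1ccc(-c2nn(-c3ccccc3)cc2C(=O)NCc2cn(Cc3ccc(OC)c(OC)c3)nn2)cc1` arises from compound 3 by 3,4-dimethoxyphenyl in place of 4-fluorophenyl on a saturated chain carbon bound to an aromatic nitrogen. Among the measured compounds shown here, no measured pair differs in only this group. Still, compound 2, which also carries a 3,4-dimethoxybenzyl group though it differs elsewhere too, gives 9400 nM. The 4-fluorobenzyl group of compound 3 is also carried by compound 1, which gives 9600 nM. Those two numbers lie within the scatter of each other, so the benzyl group seems to matter little here. The step of a 1.2-fold lower number from compound 3 to compound 4 (0.08 log units; within the scatter) is therefore expected to stay within the scatter. Compound 4 is estimated at 20000 nM, with a range from 8000 nM to 50000 nM.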

Compound 4, concentration for 50% growth inhibition: 16300 nM
The estimate for compound 4 lay 1.2-fold (0.09 log units) above the measured number; low and high end bracket the measured number.
By their numbers in this assay, from the lowest: compounds 2, 1, 4 and 3 (each within the scatter of the next, the first and the last beyond it).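

In this assay, among these compounds, 3,4-dimethoxyphenyl in place of 4-fluorophenyl on a saturated chain carbon bound to an aromatic nitrogen gives a 1.5-fold lower number from compound 3 to compound 4 (0.17 log units; within the scatter): this is the first direct reading of the swap with the rest of the molecule unchanged, and the two groups cannot be told apart here. Methoxy in place of chloro on an aromatic carbon gives a 1.7-fold higher number from compound 2 to compound 4 (0.24 log units; within the scatter), so that swap cannot be resolved either. No supporting measurement accounts for these results. On these data alone, whether an amine, a carboxylic acid or a longer chain in place of 3,4-dimethoxyphenyl would shift growth inhibition beyond the scatter remains open.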